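Adding Ethyl to the Phenoxy Group of Compound 1

The compounds below may be only part of what the source reports. "The series", "measured", "known", "first", "only" and "open" are said of these compounds alone.

Among the compounds with values here, in a functional assay on MCF7 cells (Homo sapiens) for antiproliferative activity, read by MTT assay, with a stated time of 48 h (on this read-out lower numbers stand for stronger inhibition and higher numbers for weaker inhibition), compound 1 (`O=c1cc(-n2cc(COc3ccccc3)nn2)c2cc(Br)ccc2o1`) gives 1720 nM, the lowest of the three numbers measured so far. Compound 3 (`COC(=O)c1ccccc1OCc1cn(-c2cc(=O)oc3ccc(Br)cc23)nn1`) gives 34100 nM. Compound 2 (`O=c1cc(-n2cc(COc3ccnc4ccc(Br)cc34)nn2)c2cc(Br)ccc2o1`) gives 41600 nM. Both of these numbers lie well beyond the scatter from that of compound 1.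

Compound 4 (`CCc1ccc(OCc2cn(-c3cc(=O)oc4ccc(Br)cc34)nn2)cc1`) has not yet been measured. It departs from compound 1 by a single change, ethyl in place of hydrogen on an aromatic carbon, para to a large group, which turns phenoxy into 4-ethylphenoxy.

Within the data shown here, only one measured step bears on this change. Methoxycarbonyl in place of hydrogen on an aromatic carbon gave a 20-fold higher number from compound 1 to compound 3 (1.30 log units; beyond the scatter), a large step towards weaker inhibition. Among the measured compounds shown here, that is a single example with a different group, and no measured compound carries ethyl, so it points to a direction more firmly than to a size. A rise is therefore expected, though a smaller one than that seen for compound 3 at 34100 nM. The expected change is a 2.9-fold higher number from compound 1 to compound 4 (0.46 log units; beyond the scatter), with considerable uncertainty. For compound 4 the estimated value is 5000 nM, with an expected range from 1500 nM to 20000 nM.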

Compound 4, half-maximal inhibitory concentration: 12700 nM
Compound 4: the middle estimate sits 2.5-fold (0.40 log units) below what was measured; low and high end bracket the measured number.
By their numbers in this assay, from the lowest: compound 1; then compound 4; then compounds 3 and 2 (each within the scatter of the next).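

In this assay, the new compound shows that the rise seen with methoxycarbonyl is not peculiar to that group: ethyl on an aromatic carbon, para to a large group, also weakens inhibition, giving a 7.4-fold higher number from compound 1 to compound 4 (0.87 log units; beyond the scatter). Ethyl adds only 2 carbon atoms, with no ring, 0 hydrogen-bond donors and 0 hydrogen-bond acceptors, so a change this plain is enough to move the number beyond the scatter. Alongside a 20-fold higher number from compound 1 to compound 3 (1.30 log units; beyond the scatter), this gives two substitutions on the phenyl ring of compound 1, and both lead to weaker inhibition, with no example among the compounds shown of a group on that ring lowering the number.

The compounds shown leave open whether a smaller group such as methyl or a single fluorine atom would keep the number of compound 1, and whether a longer chain such as propyl or butyl would raise it further. They also leave open whether an amine or a carboxylic acid at this same place would go the same way as ethyl. No measurement among those shown gives a reason for the rise at this position.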